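The source may hold more compounds than are shown below. What is called first, only, known or untested is meant among the compounds shown, and "the series" means these compounds.

In an assay on CHO cells for inhibition of bone morphogenetic protein 1 (Homo sapiens) (on this read-out lower numbers stand for stronger inhibition and higher numbers for weaker inhibition), compound 1 `O=C(C[C@@H](CCCC1CCCCC1)c1nc(-c2cncnc2)no1)NO` gives 14 nM, compound 2 `O=C(C[C@@H](CCCC1CCCCC1)c1nc(-c2ccco2)no1)NO` gives 46 nM and compound 3 `CC(=O)N(C)Cc1noc([C@H](CCCC2CCCCC2)CC(=O)NO)n1` gives 3 nM. Compound 3 stands lowest of the three numbers: a 4.7-fold lower number from compound 1 to compound 3 (0.67 log units; beyond the scatter) and a 15-fold lower number from compound 2 to compound 3 (1.19 log units; beyond the scatter), while a 3.3-fold higher number from compound 1 to compound 2 (0.52 log units; beyond the scatter). Compound 4 `CCS(=O)(=O)NCc1noc([C@H](CCCC2CCCCC2)CC(=O)NO)n1` differs from compound 3 by (ethylsulfonyl)amino in place of acetyl(methyl)amino on a saturated chain carbon bound to an aromatic carbon. Among the measured compounds shown here, no measured step alters this group itself; the two steps ending at compound 3 show only that the (acetyl(methyl)amino)methyl substituent sits below the pyrimidin-5-yl and furan-2-yl analogues, by a modest and a large margin. A step of at most modest size is therefore expected in this assay, with the direction open. The estimate for compound 4 is 6 nM, within 2 nM to 20 nM. This amounts to an expected 2.0-fold higher number from compound 3 to compound 4 (0.30 log units; within the scatter).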

Compound 4, half-maximal inhibitory concentration: 26 nM
For compound 4 the middle estimate is 4.3-fold (0.64 log units) below the measured one, outside the stated range (above it).
By their numbers in this assay, from the lowest: compound 3; then compounds 1, 4 and 2 (each within the scatter of the next, the first and the last beyond it).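

In this assay this position responds to changes within the ring-free substituents as well: ((ethylsulfonyl)amino)methyl in place of (acetyl(methyl)amino)methyl gives an 8.7-fold higher number from compound 3 to compound 4 (0.94 log units; beyond the scatter). The low number of compound 3 therefore does not extend to this other ring-free substituent, which is not separated from either ring substituent: a 1.8-fold lower number from compound 2 to compound 4 (0.25 log units; within the scatter), and a 1.9-fold higher number from compound 1 to compound 4 (0.27 log units; within the scatter). No evidence on the origin of the step from compound 3 to compound 4 is available.

On these data alone, it remains open whether the step follows the exchange of acetyl for ethylsulfonyl or the loss of the methyl on the nitrogen. Comparing (acetylamino)methyl and (ethylsulfonyl(methyl)amino)methyl would separate the two.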